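A few compounds are considered here, and "the series" means these few. Any claim that something is new, unique, unknown or untested is made for them only; others in the source may bear on it.

In a functional assay on HeLa cells (Homo sapiens) for antiproliferative activity, read by spectrophotometry, with a stated time of 2 days (on this read-out higher numbers stand for weaker inhibition of growth and lower numbers for stronger inhibition of growth), compound 1 `Cc1ccc(Nc2ncc(C(F)(F)F)c(N3Cc4cccc(N(C)S(C)(=O)=O)c4C3)n2)cc1C` gives > 30000 nM, which is a limit of the assay and not a number. Compound 1 therefore stands at the limit of > 30000 nM in this assay, at which 1 of the 3 values shown sits. Two relatives give true numbers in this assay: compound 2 `COc1cc(N2CCN(C(C)=O)CC2)ccc1Nc1ncc(C(F)(F)F)c(N2Cc3cccc(N(C)S(C)(=O)=O)c3C2)n1` gives 1300 nM, and compound 3 `CN(c1cccc2c1CN(c1nc(Nc3ccc(Nc4ccccc4)cc3)ncc1C(F)(F)F)C2)S(C)(=O)=O` gives 7300 nM.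

Compound 4 `Cc1cc(Cl)ccc1Nc1ncc(C(F)(F)F)c(N2Cc3cccc(N(C)S(C)(=O)=O)c3C2)n1` keeps the core of compound 1 and changes a single group: 4-chloro-2-methylphenyl in place of 3,4-dimethylphenyl on a nitrogen on an aromatic ring. Put simply, 4-chloro-2-methylphenyl takes the place of 3,4-dimethylphenyl on a nitrogen on an aromatic ring. For the measured compounds named here, no measured pair of compounds shows what this exchange does, so the expectation starts from compound 1 at > 30000 nM.

Only a small change is expected, in the direction of stronger inhibition of growth if it appears at all. The estimated step is an at least 1.6-fold lower number from compound 1 to compound 4 (0.22 log units; that floor lies within the scatter), and it may not rise beyond the usual scatter. For compound 4 the expected value is 18000 nM, with an estimated range from 6000 nM to 35000 nM.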

Compound 4, concentration for 50% growth inhibition: 17400 nM
Compound 4: the middle estimate sits 1.0-fold (0.01 log units) above what was measured, and the stated range covers the measured number.
By their numbers in this assay, from the lowest: compound 2; then compound 3; then compound 4. At a limit, above all of these: compound 1.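

This exchange is the first change in a single place among the compounds shown, and in this assay 4-chloro-2-methylphenyl in place of 3,4-dimethylphenyl gives an at least 1.7-fold lower number from compound 1 to compound 4 (0.23 log units; that floor lies within the scatter). It shows that this position, on a nitrogen on an aromatic ring, can carry a ring that brings a true number in this read-out, with compound 4 at 17400 nM, while both groups remain six-membered aromatic rings of carbon only. The reading for compound 1 is a limit of the assay and not a number: the limit of > 30000 nM in this assay, at which 1 of the 4 values shown sits.

The compounds shown leave open whether the chlorine or the changed place of the methyl group accounts for the step, since both differ in this one exchange. They also leave open how a ring carrying an amine or a carboxylic acid would read at this position.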